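The compounds below may be only part of what the source reports. "The series", "measured", "known", "first", "only" and "open" are said of these compounds alone.

Measured compounds:
- compound 1, `N#C/C(=C\c1c(-c2ccccc2)[nH]c2ccccc12)C(=O)c1ccccc1`: "not determined" (no result reported) in a functional assay on SK-MEL-5 cells (Homo sapiens) for inhibition, read by sulforhodamine B assay, with a stated time of 48 h; on this read-out lower numbers stand for stronger inhibition of growth and higher numbers for weaker inhibition of growth
- compound 2, `O=C(/C(=C\c1c(-c2ccccc2)[nH]c2ccccc12)S(=O)(=O)c1ccccc1)c1ccccc1`: 9000 nM
- compound 3, `COc1ccc(-c2[nH]c3ccc(OC)cc3c2/C=C(\C#N)S(=O)(=O)c2ccccc2)cc1`: 319 nM

Among the measured compounds shown here, compound 2 stands at the highest of the two numbers available in this assay; the only other number, that of compound 3, lies far lower, and the gap between the two is well beyond the usual scatter of this assay. Compound 3 differs from compound 2 in several places at once, so the two values say nothing about any single change.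

Compound 4, `CC(=O)/C(=C\c1c(-c2ccccc2)[nH]c2ccccc12)S(=O)(=O)c1ccccc1`, differs from compound 2 in one place: methyl in place of phenyl on a carbonyl carbon. Seen one bond further out, a benzoyl becomes an acetyl. For the measured compounds named here, no measured pair shows this change, so there is no direct guide to its effect. A change that only trims a phenyl to a methyl, with no gain or loss of donors or acceptors, is expected to move the number little, with no clear direction, and most likely not beyond the scatter.

For compound 4 in this assay the estimated value is 8000 nM, with a range from 2000 nM to 30000 nM. This estimate means an expected step of a 1.1-fold lower number from compound 2 to compound 4 (0.05 log units; within the scatter), which is expected to stay within the scatter.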

Compound 4, concentration for 50% growth inhibition: 832 nM
Estimate against measurement, compound 4: 9.6-fold (0.98 log units) above; measured number outside the range, below it.
By their numbers in this assay, from the lowest: compound 3; then compound 4; then compound 2.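

In this assay the change from benzoyl to acetyl brings an 11-fold lower number from compound 2 to compound 4 (1.03 log units; beyond the scatter) and so reaches well beyond the scatter. Among the compounds shown here, this is the first comparison here in which only one place differs, and it shows that the group on this carbonyl carbon matters for growth inhibition. The phenyl is not needed there for the activity seen in this assay, as the much smaller methyl gives the stronger inhibition, even though neither group has any hydrogen-bond donors or acceptors to count. Nothing measured here explains this step.

From the compounds shown here alone, whether an ethyl or an amine on this carbonyl carbon would lower the number further, or raise it again, remains open. Also open, going by these compounds, is whether the same change would have a similar effect in a compound carrying the methoxy groups of compound 3.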